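The source may hold more compounds than are shown below. What is called first, only, known or untested is meant among the compounds shown, and "the series" means these compounds.

Working notes on the series in a functional assay on MGC-803 cells (Homo sapiens) for inhibition, read by MTT assay, with a stated time of 72 h; a higher number here means a weaker inhibitor, a lower number a stronger inhibitor. Among the measured compounds shown here, only two compounds have been run. For the measured compounds named here, compound 1 `N#Cc1c(Nc2ccccc2Cl)nc(SCc2cn(Cc3ccccc3Cl)nn2)nc1-c1ccccc1` gives 4640 nM in this assay, and this is the single plain number in hand. Compound 2 `N#Cc1c(Nc2ccccc2F)nc(SCc2cn(Cc3ccc(Cl)cc3)nn2)nc1-c1ccccc1` comes back only as a limit of the assay, > 64000 nM, so no number exists for it. The pattern of values in this assay is therefore (the limit of > 64000 nM in this assay, at which 1 of the 2 values shown sits), and compound 1 stands alone as the one measured point; nothing can be said of the gap between compound 1 and compound 2 beyond that.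

Compound 3 `Cc1ccc(Nc2nc(SCc3cn(Cc4ccccc4Cl)nn3)nc(-c3ccccc3)c2C#N)cc1` has not been measured. It differs from compound 1 by 4-methylphenyl in place of 2-chlorophenyl on a nitrogen on an aromatic ring. Going by the values given here, no measured pair isolates this change, so no step size is known. The step from compound 1 to compound 3 is expected to be small, a 1.3-fold higher number from compound 1 to compound 3 (0.11 log units; within the scatter), within the scatter. Compound 3 is thus estimated at 6000 nM, with a range from 1500 nM to 25000 nM.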

Compound 3, half-maximal inhibitory concentration: 7190 nM
Beside the measured number, compound 3's estimate is 1.2-fold (0.08 log units) below it; measured number inside the range.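

Among the compounds shown here, the step of a 1.5-fold higher number from compound 1 to compound 3 (0.19 log units; within the scatter) is the first reading at this position in this assay, and it places the two compounds level. On this pair, the 2-chlorophenyl group is not required to keep the value, and 4-methylphenyl on the same nitrogen serves equally well. Nothing in hand gives a cause for this result.

The swap moves the ring substituent and replaces chlorine with methyl in one step, so the separate contributions of the two remain unresolved until 4-chlorophenyl and 2-methylphenyl groups are read at this nitrogen. Also open, going by these compounds, is the response to a phenyl ring carrying a carboxylic acid or an amine, and to a non-aromatic group such as cyclohexyl in place of the ring.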